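This account rests on a few compounds, and the source may have more. Where it says the series, first, only, none or still open, it means among the compounds named here.

Three compounds have been measured in an ADME assay on HEK293 cells (Homo sapiens) for cytotoxicity, with a stated time of 72 h; on this read-out lower numbers stand for an effect already at smaller amounts and higher numbers for an effect only at larger amounts of compound:

Compound 1 `Cc1cc(NC(=O)Nc2ccc([N+](=O)[O-])c(C(F)(F)F)c2)c2ccccc2n1` gives > 25000 nM, a limit of the assay.
Compound 2 `Cc1cc(NC(=O)Nc2ccc(C(=O)O)cc2)c2ccccc2n1` gives > 25000 nM, a limit of the assay.
Compound 3 `Cc1cc(NC(=O)Nc2ncccc2C)c2ccccc2n1` gives > 25000 nM, a limit of the assay.

Compound 3 therefore stands exactly where the other two stand, at the limit of > 25000 nM in this assay, at which 3 of the 3 values shown sit; no number separates any of the three. Compound 4 `Cc1cc(NC(=O)Nc2ccccc2N)c2ccccc2n1` differs from compound 3 in a single place: 2-aminophenyl in place of 3-methylpyridin-2-yl on an amide-type nitrogen. Within the data shown here, no step between measured compounds is available to gauge this change. In this assay a step no larger than the usual scatter is expected, in no particular direction, and another limit seems the most probable outcome. Compound 4 is estimated at 30000 nM, with a range from 8000 nM to 100000 nM. That estimate means an expected step that the limit leaves unreadable from compound 3 to compound 4.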

Compound 4, half-maximal effective concentration: > 25000 nM
Compound 4: a limit, no number; the forecaster's own chance of this, stated with the estimate: 80%; the middle value lies beyond the limit too.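

Compound 3 and compound 4 both give only a limit in this assay, and no step can be read between them. The compounds shown leave open at what concentration any of them would reach a half-maximal effect, all sharing one result: the limit of > 25000 nM in this assay, at which 4 of the 4 values shown sit.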